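The source may hold more compounds than are shown below. What is called first, only, known or untested is meant among the compounds shown, and "the series" means these compounds.

Measured so far:
compound 1 `Cn1c(=O)c(S(=O)(=O)c2ccc(F)cc2F)cc2cnc(Nc3ccc4[nH]c(C(=O)O)cc4c3)nc21`: 10000 nM
compound 2 `Cn1c(=O)c(C(=O)Nc2ccc(F)cc2F)cc2cnc(Nc3ccc4[nH]ccc4c3)nc21`: 5000 nM
compound 3 `Cn1c(=O)c(S(=O)(=O)Cc2ccc(F)cc2F)cc2cnc(Nc3ccc4[nH]ccc4c3)nc21`: 1000 nM

All three compounds were tested in a functional assay on K562 cells (Homo sapiens) for inhibition, read by trypan blue exclusion, with a stated time of 72 h; on this read-out higher numbers stand for weaker inhibition and lower numbers for stronger inhibition. In this assay, compound 1 gives 10000 nM and sits at the weak end of this small set. It shares that end with compound 2, since the two values lie within the scatter of each other. Compound 3 stands apart from compound 1, beyond the scatter, with stronger inhibition.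

The next compound to be tested is compound 4 `Cn1ccc2cc(Nc3ncc4cc(S(=O)(=O)c5ccc(F)cc5F)c(=O)n(C)c4n3)ccc21`. It keeps the core of compound 1 but carries 1-methyl-1H-indol-5-yl in place of 2-carboxy-1H-indol-5-yl on a nitrogen on an aromatic ring.

Within the data shown here, no measured pair isolates this change, so its size in this assay can only be judged indirectly. Compound 3 lacks the carboxy group and reads 1000 nM, which points towards stronger inhibition. Compound 2 also lacks it and reads 5000 nM, which goes against that reading, so the expectation is a moderate one. The expected step is a 5.0-fold lower number from compound 1 to compound 4 (0.70 log units; beyond the scatter), in the direction of stronger inhibition. The estimated value for compound 4 is 2000 nM, with an expected range from 400 nM to 8000 nM.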

Compound 4, half-maximal inhibitory concentration: 750 nM
Beside the measured number, compound 4's estimate is 2.7-fold (0.43 log units) above it, within the range that was stated.
By their numbers in this assay, from the lowest: compounds 4 and 3 (each within the scatter of the next); then compounds 2 and 1 (each within the scatter of the next).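

In this assay, replacing 2-carboxy-1H-indol-5-yl with 1-methyl-1H-indol-5-yl on a nitrogen on an aromatic ring gives a 13-fold lower number from compound 1 to compound 4 (1.12 log units; beyond the scatter), a large step towards stronger inhibition. Among these compounds, this is the first reading in which this place is the only one that differs, as no earlier pair isolated a single change. The step combines two edits, the loss of the carboxy group and the gain of the methyl group, and the count of hydrogen-bond donors falls from 2 to 0 across it, so the result shows the effect of the whole exchange but not the share of either edit, and nothing given here explains its size.

The compounds shown leave open how the step divides between those two edits, which plain 1H-indol-5-yl on the same core would help to settle. They also leave open how an ethyl ester or a primary amide in place of the carboxylic acid, or a longer chain such as 1-propyl in place of the methyl group, would read in this assay.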